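From Pyrrolidin-1-yl to 2-Oxopyrrolidin-1-yl: Cytotoxicity Outlook

The source may hold more compounds than are shown below. What is called first, only, known or untested is meant among the compounds shown, and "the series" means these compounds.

Measured so far, in an ADME assay on HEL cells (Homo sapiens) for cytotoxicity, with a stated time of 3 days; on this read-out lower numbers stand for higher toxicity in this test and higher numbers for lower toxicity in this test:
Compound 1, `Cc1cc(-c2ccoc2)cn2c(CSCCc3ccccc3)cnc12`, gives > 4 ug/mL, which is a limit of the assay and not a number.
Compound 2, `Cc1cc(N2CCCC2)cn2c(CSCCc3ccccc3)cnc12`, gives 20 ug/mL.

Compound 2 thus stands on the only number shown in this assay; the one further value, that of compound 1, is a limit. Compound 3 is `Cc1cc(N2CCCC2=O)cn2c(CSCCc3ccccc3)cnc12`. It differs from compound 2 in one place: 2-oxopyrrolidin-1-yl in place of pyrrolidin-1-yl on an aromatic carbon.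

Going by the values given here, only one measured step exists, a step that the limit leaves unreadable from compound 1 to compound 2, and it is unreadable because compound 1 sits at the limit of > 4 ug/mL in this assay, at which 1 of the 2 values shown sits. Among the compounds with values here, no measured step therefore speaks to the exchange of pyrrolidin-1-yl for 2-oxopyrrolidin-1-yl, and nothing in the numbers points to a shift in either direction. The step from compound 2 to compound 3 in this assay is expected to be no change at the digits printed from compound 2 to compound 3 (within the scatter), that is, none beyond the scatter. For compound 3 the estimated minimum cytotoxic concentration is 20 ug/mL, with a range from 7 ug/mL to 60 ug/mL.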

Compound 3, minimum cytotoxic concentration: > 100 ug/mL
Compound 3 gave a limit, no number; the forecaster's own chance of this, stated with the estimate: 35%; middle value at least 5.0-fold (0.69 log units) from the limit.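

In this assay, going by these compounds alone, the exchange of pyrrolidin-1-yl for 2-oxopyrrolidin-1-yl gives an at least 5.0-fold higher number from compound 2 to compound 3 (0.69 log units; beyond the scatter), the first step at this position on the aromatic carbon, para to a fused ring, that can be read at all. Compound 3 gives > 100 ug/mL, which is a limit of the assay and not a number. The two groups have the same five-membered non-aromatic ring and the same count of hydrogen-bond donors and acceptors, and they differ by the one oxygen that enters as a carbonyl, so this small change in the ring is enough to carry the read-out beyond the scatter in the direction of lower toxicity in this test.

Going by these compounds, the steps that involve compound 1 cannot be read, so furan-3-yl cannot be placed against either of the two ring groups, and the full size of the step to compound 3 also stays unknown. The compounds shown also leave open whether the same step would appear with the carbonyl in a piperidin-1-yl ring, as 2-oxopiperidin-1-yl, or in an open-chain acetamide at this position.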